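Benzylsulfanyl chain terminus in the alpha-ketooxazole series

The source may hold more compounds than are shown below. What is called first, only, known or untested is meant among the compounds shown, and "the series" means these compounds.

Among the measured compounds shown here, compound 3 `O=C(CCCCCCc1ccccn1)c1ncc(-c2ccccn2)o1` gives the lowest number of the three compounds measured so far in an assay for inhibition of Fatty-acid amide hydrolase 1 (Rattus norvegicus); a lower number here means a stronger inhibitor, a higher number a weaker inhibitor: compound 3 gives 120 nM. Its nearest neighbour is compound 2 `O=C(CCCCC#Cc1ccncc1)c1ncc(-c2ccccn2)o1`, which in this assay gives 150 nM, and the two lie within the scatter of each other. Compound 1 `O=C(CCCCC#Cc1ccccn1)c1ncc(-c2ccccn2)o1` gives 280 nM, so that the step of a 2.3-fold lower number from compound 1 to compound 3 (0.37 log units; beyond the scatter) is modest but beyond the scatter, while the step of a 1.9-fold lower number from compound 1 to compound 2 (0.27 log units; within the scatter) and the step of a 1.3-fold lower number from compound 2 to compound 3 (0.10 log units; within the scatter) both stay within it.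

Compound 4 `O=C(CCCCSCc1ccccc1)c1ncc(-c2ccccn2)o1` has not yet been measured. It differs from compound 3 by benzylsulfanyl in place of 2-(pyridin-2-yl)ethyl on a saturated chain carbon, four bonds along the chain from a carbonyl carbon. For the measured compounds named here, none of the measured steps carries the same change: the step of a 2.3-fold lower number from compound 1 to compound 3 (0.37 log units; beyond the scatter) concerns only the saturation of the chain, and the step of a 1.9-fold lower number from compound 1 to compound 2 (0.27 log units; within the scatter) only the point at which the nitrogen sits in the ring. Nothing in the measured set introduces a sulfur into the chain or removes the ring nitrogen altogether, so the size of the step in this assay can be judged only loosely; a step no larger than the modest ones already seen, in either direction, is the expectation. Compound 4 is therefore expected to give about 60 nM in this assay, within a range of 15 nM to 250 nM, meaning an expected step of a 2.0-fold lower number from compound 3 to compound 4 (0.30 log units; within the scatter).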

Compound 4, inhibition constant: 25 nM
Compound 4: the middle estimate sits 2.4-fold (0.38 log units) above what was measured; the measured number falls inside the stated range.
By their numbers in this assay, from the lowest: compound 4; then compounds 3, 2 and 1 (each within the scatter of the next, the first and the last beyond it).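

Working notes, terminus of the chain: in this assay this position, on a saturated chain carbon, four bonds along the chain from a carbonyl carbon, proves able to carry a much larger effect than the earlier pyridine termini suggested, with a 4.8-fold lower number from compound 3 to compound 4 (0.68 log units; beyond the scatter) and a 6.0-fold lower number from compound 2 to compound 4 (0.78 log units; beyond the scatter) and finally an 11-fold lower number from compound 1 to compound 4 (1.05 log units; beyond the scatter) making compound 4 the strongest inhibitor of the four. The earlier steps shown here varied only the place of the ring nitrogen and the saturation of the chain, whereas here 2-(pyridin-2-yl)ethyl and benzylsulfanyl, with 8 heavy atoms each, differ by a sulfur in the chain and a ring of carbon only. These two differences arrive together in a single step, and no measurement at hand accounts for the gain.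

The share of the sulfur and the share of the all-carbon ring remain unseparated, and a 3-phenylpropyl-type all-carbon terminus set against a (pyridin-2-ylmethyl)sulfanyl terminus would divide them. Also open, going by these compounds, is how far the gain extends to a chlorine or methoxy group on the benzyl ring, or to a longer chain ahead of the sulfur.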